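Solubility notes on the aryl series sharing one core

The source may report more compounds than this note shows. Statements on the series, on what has been measured and on what is new or still open speak of the compounds shown alone.

Three compounds of this series have been measured in a physicochemical assay for solubility, read by LC-MS, in phosphate buffer, measured as thermodynamic solubility, with a stated time of 24 h, at pH 7.4; on this read-out lower numbers stand for lower solubility and higher numbers for higher solubility:

- compound 1, `Cn1cc(-c2cnc3[nH]cc(-c4cccc(C(F)(F)F)c4)c3c2)cn1`, gives 1000 nM
- compound 2, `Cn1cc(-c2cnc3[nH]cc(-c4cccc(F)c4)c3c2)cn1`, gives 3000 nM
- compound 3, `Cn1cc(-c2cnc3[nH]cc(-c4cccc([N+](=O)[O-])c4)c3c2)cn1`, gives 2000 nM

Compound 2 carries the largest number of the three. Its gap to compound 3 is within the scatter (a 1.5-fold lower number from compound 2 to compound 3 (0.18 log units; within the scatter)), whereas the step from compound 1 is beyond it (a 3.0-fold higher number from compound 1 to compound 2 (0.48 log units; beyond the scatter)); the step from compound 1 to compound 3 is a 2.0-fold higher number from compound 1 to compound 3 (0.30 log units; within the scatter).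

Compound 4, `Cn1cc(-c2cnc3[nH]cc(-c4cccnc4)c3c2)cn1`, is next in line for this assay. Relative to compound 2 the change is pyridin-3-yl in place of 3-fluorophenyl on an aromatic carbon. Within the data shown here, none of the measured steps swaps the ring itself; all three exchange a single substituent on the phenyl ring, and the largest of them, a 3.0-fold higher number from compound 1 to compound 2 (0.48 log units; beyond the scatter), is only modest. The change to compound 4 goes beyond those precedents, so the direct evidence is thin. On the numbers at hand a modest rise for compound 4 is expected, a 2.0-fold higher number from compound 2 to compound 4 (0.30 log units; within the scatter), with a wide range. The estimate for compound 4 in this assay is 6000 nM, expected to fall between 2500 nM and 15000 nM.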

Compound 4, solubility: 97000 nM
The estimate for compound 4 lay 16-fold (1.21 log units) below the measured number, and the stated range ends below it.
By their numbers in this assay, from the lowest: compounds 1, 3 and 2 (each within the scatter of the next, the first and the last beyond it); then compound 4.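

In this assay, among these compounds, the exchange of the whole aryl ring at this place gives a 32-fold higher number from compound 2 to compound 4 (1.51 log units; beyond the scatter) and reaches well past the largest substituent exchange on the phenyl ring among the earlier compounds, which is a 3.0-fold higher number from compound 1 to compound 2 (0.48 log units; beyond the scatter) in the same direction. Among the compounds shown here, the earlier steps left the carbon-only ring in place, so this is the first view of the series with a hetero atom in that ring, and the size of the step shows that the ring itself matters more here than any of the three substituents compared so far. For the compounds shown here, the single step changes two things at once, since the fluoro substituent leaves as the ring nitrogen enters, and nothing measured here accounts for the size of the rise.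

Unsubstituted phenyl at this place would show how much of the step belongs to the loss of fluoro and how much to the ring nitrogen, and the compounds shown do not settle that split. Also open, on these data alone, is how the number responds when an amine, a carboxylic acid or a methoxy group sits on the pyridin-3-yl ring.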